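This account rests on a few compounds, and the source may have more. Where it says the series, first, only, none or still open, it means among the compounds named here.

Compound 3 `COc1ccc(/C=C2\CCN=C2c2cccnc2)c(O)c1` carries one hydroxy and one methoxy group on its phenyl ring. Going by the values given here, in an assay for displacement of a labelled ligand from Nicotinic acetylcholine receptor alpha8 subunit (Periplaneta americana), read by scintillation counting, with a stated time of 2 h, at 24 degrees C (a lower number here means a stronger inhibitor, a higher number a weaker inhibitor), compound 3 gives 3890 nM, the second highest of the three numbers measured so far. Compound 1 `Oc1ccc(/C=C2\CCN=C2c2cccnc2)c(O)c1`, which bears two hydroxy groups, gives 120 nM in this assay, and compound 2 `Oc1ccccc1/C=C1\CCN=C1c1cccnc1`, which keeps only one hydroxy, gives 6900 nM. The step from compound 1 to compound 3 shows a 32-fold higher number from compound 1 to compound 3 (1.51 log units; beyond the scatter), and the step from compound 1 to compound 2 shows a 58-fold higher number from compound 1 to compound 2 (1.76 log units; beyond the scatter), while between compound 2 and compound 3 there is a 1.8-fold lower number from compound 2 to compound 3 (0.25 log units; within the scatter).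

Compound 4 `COc1ccc(/C=C2\CCN=C2c2cccnc2)c(OC)c1` differs from compound 3 by methyl in place of hydrogen on an oxygen on an aromatic ring. This is the same kind of change that separates compound 1 from compound 3, where it produced a large loss; removing a hydroxy altogether, as from compound 1 to compound 2, also cost a great deal. The remaining hydroxy of compound 3 is therefore expected to matter, and compound 4 is expected to give a weaker result, with an anticipated step of a 13-fold higher number from compound 3 to compound 4 (1.11 log units; beyond the scatter). Compound 4 is estimated at 50000 nM in this assay, within a range of 10000 nM to 200000 nM.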

Compound 4, half-maximal inhibitory concentration: 4550 nM
The estimate for compound 4 lay 11-fold (1.04 log units) above the measured number, and the stated range ends above it.
By their numbers in this assay, from the lowest: compound 1; then compounds 3, 4 and 2 (each within the scatter of the next).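

The same replacement of hydroxy by methoxy reads very differently in two places: in this assay there is a 1.2-fold higher number from compound 3 to compound 4 (0.07 log units; within the scatter), against a 32-fold higher number from compound 1 to compound 3 (1.51 log units; beyond the scatter). Once compound 3 has lost the low number of compound 1, methylating the hydroxy it still carries makes no readable difference, so that remaining free hydroxy is not required on its own to hold the number at the level seen for compound 3, and among these compounds only compound 1, with two hydroxy groups, stands apart. No measurement given here bears on why the same change has such different outcomes.

The compounds shown leave open whether the low number of compound 1 depends on both hydroxy groups together or on just the one that is methylated in compound 3, since the two steps differ in which oxygen carries the new methyl and in what else the ring bears. They also leave open how that oxygen position would respond to an amine in place of the hydroxy, or to a longer chain such as ethoxy.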